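Dropping both methoxy groups from the benzyl of compound 2

This account rests on a few compounds, and the source may have more. Where it says the series, first, only, none or still open, it means among the compounds named here.

Of the compounds shown here, two built on the same core have so far been measured in a functional assay on ASPC1 cells (Homo sapiens) for inhibition, read by MTT assay, with a stated time of 72 h; a higher number here means a weaker inhibitor of growth, a lower number a stronger inhibitor of growth. Compound 1 `O=S(=O)(NCCNCc1cccc2ccccc12)c1cc(C(F)(F)F)cc(C(F)(F)F)c1` gives 22000 nM there. Compound 2 `COc1ccc(CNCCCNS(=O)(=O)c2cc(C(F)(F)F)cc(C(F)(F)F)c2)cc1OC` gives 6400 nM in this assay. Compound 2 therefore holds the lower of the two numbers, and its gap to compound 1 lies beyond the scatter. Compound 3 `O=S(=O)(NCCCNCc1ccccc1)c1cc(C(F)(F)F)cc(C(F)(F)F)c1` has not yet been measured. It differs from compound 2 in one place: phenyl in place of 3,4-dimethoxyphenyl on a saturated chain carbon bound to an amine nitrogen. Among the measured compounds shown here, no measured pair shows this change by itself, and compound 1 and compound 2 differ in more than one place, so their two values say nothing about what the methoxy groups contribute. A modest move toward a higher number, of a size near the edge of the scatter, is expected. Compound 3 is therefore expected to give about 12000 nM in this assay, within a range of 4000 nM to 40000 nM. This estimate corresponds to a step of a 1.9-fold higher number from compound 2 to compound 3 (0.27 log units; within the scatter).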

Compound 3, concentration for 50% growth inhibition: 13000 nM
Compound 3: the middle estimate sits 1.1-fold (0.03 log units) below what was measured; the range from low to high includes it.
By their numbers in this assay, from the lowest: compound 2; then compounds 3 and 1 (each within the scatter of the next).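

Among the compounds shown here, replacing 3,4-dimethoxyphenyl with phenyl on a saturated chain carbon bound to an amine nitrogen gives the first reading of this change by itself in this assay, and the result is a 2.0-fold higher number from compound 2 to compound 3 (0.31 log units; beyond the scatter), a modest step that lies only just beyond the usual scatter. The two methoxy groups are therefore not needed for a measurable reading, since compound 3, which lacks both, still gives 13000 nM, and here they go with only a small gain. Nothing at hand offers an explanation for this step.

The compounds shown leave open whether a single methoxy group would match the 3,4-dimethoxyphenyl of compound 2, and what a chlorine or a hydroxyl on the phenyl would do. For the compounds shown here, they also leave open what a longer chain would do on its own, as no pair here differs in the chain alone.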